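The source may hold more compounds than are shown below. What is called first, only, known or untested is meant among the compounds shown, and "the series" means these compounds.

Compound 1 `CC(=O)N(C)c1ccc2[nH]c(-c3n[nH]c4ccccc34)cc2n1`, compound 2 `COc1cccc(C(=O)N(C)c2ccc3[nH]c(-c4n[nH]c5ccccc45)cc3n2)c1` and compound 3 `CN(c1ccc2[nH]c(-c3n[nH]c4ccccc34)cc2n1)S(=O)(=O)c1ccccc1` share one core and differ only in the group carried by the methylated nitrogen on the aromatic ring. In a functional assay on HL-60 cells (Homo sapiens) for antiproliferative activity, read by MTT assay, with a stated time of 72 h (on this read-out lower numbers stand for stronger inhibition and higher numbers for weaker inhibition), compound 1 gives 5110 nM, compound 2 gives 1420 nM, and compound 3 gives 3700 nM. Among these three numbers compound 3 stands second highest: it lies nearest to compound 1, with a 1.4-fold lower number from compound 1 to compound 3 (0.14 log units; within the scatter), and furthest from compound 2, with a 2.6-fold higher number from compound 2 to compound 3 (0.42 log units; beyond the scatter).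

Compound 4 `CN(c1ccc2[nH]c(-c3n[nH]c4ccccc34)cc2n1)S(=O)(=O)c1cccc([N+](=O)[O-])c1` differs from compound 3 in one place: nitro in place of hydrogen on an aromatic carbon. Within the data shown here, no measured step adds a substituent to an aromatic ring in this way. The known steps are a 3.6-fold lower number from compound 1 to compound 2 (0.56 log units; beyond the scatter), which enlarges the group on the carbonyl carbon, and a 2.6-fold higher number from compound 2 to compound 3 (0.42 log units; beyond the scatter), which exchanges the whole group on the nitrogen; neither tells what a nitro on the phenylsulfonyl does, so no step beyond the scatter is expected in this assay. For compound 4 the expected value is 3000 nM, within a range from 1000 nM to 9000 nM. The step expected for compound 4 is a 1.2-fold lower number from compound 3 to compound 4 (0.09 log units; within the scatter).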

Compound 4, half-maximal inhibitory concentration: 3660 nM
Compound 4: middle estimate off by 1.2-fold (0.09 log units), on the low side; measured number inside the range.
By their numbers in this assay, from the lowest: compound 2; then compounds 4, 3 and 1 (each within the scatter of the next).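

In this assay, nitro in place of hydrogen on an aromatic carbon, meta to a large group, gives a 1.0-fold lower number from compound 3 to compound 4 (0.00 log units; within the scatter), so phenyl can become 3-nitrophenyl on the sulfonyl without a change that this assay can detect. The earlier steps shown here swapped the group on the carbonyl carbon or the whole group on the nitrogen, whereas this one alters the phenylsulfonyl group only by a substituent on its ring, and that ring carbon accepts the added nitro with no shift in the number. Nothing measured here gives a reason for this result.

From the compounds shown here alone, it remains open whether an amine or a carboxylic acid on the same carbon would also leave the number in place. The compounds shown also do not tell whether nitro on another carbon of this ring would behave in the same way.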